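The source may report more compounds than this note shows. Statements on the series, on what has been measured and on what is new or still open speak of the compounds shown alone.

Measured in a functional assay on DU-145 cells (Homo sapiens) for inhibition, read by trypan blue exclusion, with a stated time of 96 h; a lower number here means a stronger inhibitor of growth, a higher number a weaker inhibitor of growth:
- compound 1 `Cc1ccc(S/C(=C/c2ccc(N(C)C)cc2)C(=O)c2ccc(Cl)cc2)cc1` gives > 100000 nM (a limit)
- compound 2 `Cc1ccc(S/C(=C/c2sccc2C)C(=O)c2ccc(Cl)cc2)cc1` gives 50000 nM
- compound 3 `COc1ccc(/C=C(/Sc2ccc(C)cc2)C(=O)c2ccc(Cl)cc2)cc1O` gives 1000 nM

Compound 1 stands at the limit of > 100000 nM in this assay, at which 1 of the 3 values shown sits, so its entry is a limit and not a number. Compound 4 `Cc1ccc(S(=O)(=O)/C(=C/c2ccc(N(C)C)cc2)C(=O)c2ccc(Cl)cc2)cc1` differs from compound 1 in one place: (4-methylphenyl)sulfonyl in place of (4-methylphenyl)sulfanyl on a double-bonded chain carbon bound to a carbonyl carbon and a double-bonded chain carbon. For the measured compounds named here, no measured step touches that place. All of them replace the group on a double-bonded chain carbon bound to a double-bonded chain carbon: an at least 2.0-fold lower number from compound 1 to compound 2 (0.30 log units; that floor lies within the scatter), an at least 100-fold lower number from compound 1 to compound 3 (2.00 log units; beyond the scatter) and a 50-fold lower number from compound 2 to compound 3 (1.70 log units; beyond the scatter). The last two are large. Compound 4 keeps the 4-(dimethylamino)phenyl group of compound 1, so no step beyond the scatter is expected in this assay. The expected step is an at least 1.6-fold lower number from compound 1 to compound 4 (0.22 log units; that floor lies within the scatter). The estimate for compound 4 is 60000 nM, with an expected range from 10000 nM to 100000 nM.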

Compound 4, concentration for 50% growth inhibition: > 100000 nM
Compound 4 was reported as a limit; the forecaster's own chance of this, stated with the estimate: 50%; middle value at least 1.6-fold (0.22 log units) away from the limit.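

In this assay compound 1 and compound 4 each stand at a limit and not a number, so no step between them can be read: the limit of > 100000 nM in this assay, at which 2 of the 4 values shown sit.

The compounds shown leave open whether (4-methylphenyl)sulfonyl in place of (4-methylphenyl)sulfanyl changes growth inhibition at all.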